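Dichlorophenyl for nitrophenyl on a chalcone-bearing core

The source may report more compounds than this note shows. Statements on the series, on what has been measured and on what is new or still open speak of the compounds shown alone.

Measured compounds:
- compound 1, `CNC(=O)c1cc(Oc2ccc(C(=O)/C=C/c3cccc([N+](=O)[O-])c3)cc2)ccn1`: "not determined" (no result reported)
- compound 2, `CNC(=O)c1cc(Oc2ccc(C(=O)/C=C/c3cc(OC)c(OC)c(OC)c3)cc2)ccn1`: 3150 nM
- compound 3, `CNC(=O)c1cc(Oc2ccc(/C=C/C(=O)c3ccc(Cl)cc3)cc2)ccn1`: "not determined" (no result reported)

In a functional assay on PC-3 cells (Homo sapiens) for cytotoxicity, read by MTT assay, with a stated time of 72 h (on this read-out lower numbers stand for stronger inhibition and higher numbers for weaker inhibition), compound 1 has no number; its entry reads "not determined" (no result reported). Compound 3 is in the same position, with "not determined" (no result reported) in this assay. The only numerical result in this assay belongs to compound 2, which gives 3150 nM. Compound 1 therefore stands on no value of its own, and one further entry in the set also lacks a number.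

The unmeasured compound 4, `CNC(=O)c1cc(Oc2ccc(C(=O)/C=C/c3ccc(Cl)cc3Cl)cc2)ccn1`, differs from compound 1 in one place: 2,4-dichlorophenyl in place of 3-nitrophenyl on a double-bonded chain carbon bound to a double-bonded chain carbon. Among the compounds with values here, no measured pair differs in one place, so no step between measured compounds is available, and because compound 1 itself has no number, neither the size nor the direction of the step to compound 4 in this assay can be stated; any comparison has to rest on compound 2 alone.

On that basis, compound 4 is expected to give roughly 3000 nM in this assay, with a range from 700 nM to 13000 nM, and the estimate is a guess anchored on compound 2's 3150 nM rather than on any shown step.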

Compound 4, half-maximal inhibitory concentration: 9220 nM
Beside the measured number, compound 4's estimate is 3.1-fold (0.49 log units) below it; measured number inside the range.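

In this assay, within the data shown here, compound 1 stands without a single number, so no step to compound 4 can be read. The compounds shown leave open how far, and in which direction, replacing 3-nitrophenyl with 2,4-dichlorophenyl shifts the read-out on the shared core. No supporting evidence bears on this result.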